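Sulfonamide series: aryl swap on the sulfonyl sulfur

The source may report more compounds than this note shows. Statements on the series, on what has been measured and on what is new or still open speak of the compounds shown alone.

Working notes on the series. Compound 2 `O=S(=O)(Nc1ccc(-c2nc3ccccc3o2)cc1)c1ccc(Cl)s1` is the starting point for this step. In an ADME assay on HEK293 cells (Homo sapiens) for cytotoxicity, read by resazurin assay, with a stated time of 48 h (a higher number here means that more compound is tolerated, a lower number that less compound is tolerated), compound 2 reaches only the assay limit of > 100000 nM. Two further compounds are in hand, compound 1 `O=S(=O)(Nc1ccc2oc(-c3ccccc3)nc2c1)c1cccc(C(F)(F)F)c1` and compound 3 `O=S(=O)(Nc1ccc2oc(-c3ccccc3)nc2c1)c1cccc(O)c1`. In this assay compound 1 gives only the limit > 100000 nM. In this assay compound 3 likewise gives only the limit > 100000 nM. Among the measured compounds shown here, the one single-point step, a step that the two limits leave unreadable from compound 1 to compound 3, cannot be read because of the limit of > 100000 nM in this assay, at which 3 of the 3 values shown sit. Compound 4 `O=S(=O)(Nc1ccc(-c2nc3ccccc3o2)cc1)c1ccc(O)cc1` is the next member: 4-hydroxyphenyl in place of 5-chlorothiophen-2-yl on a sulfonyl sulfur. For the measured compounds named here, no measured step touches the sulfonyl sulfur, and no step in the set has a readable size. Compound 4 is therefore expected to stay close to compound 2, a number no higher from compound 2 to compound 4 (the limit leaves the size open). The estimate for compound 4 is 100000 nM, from 40000 nM to 250000 nM.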

Compound 4, half-maximal cytotoxic concentration: > 100000 nM
Compound 4 ended at the assay's limit (the forecaster's own chance of this, stated with the estimate: 85%); the middle value lies on the limit itself.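

The step from compound 2 to compound 4 cannot be read, because both compounds give only a limit: the limit of > 100000 nM in this assay, at which 4 of the 4 values shown sit. The compounds shown leave open whether any group on the sulfonyl sulfur changes tolerance in this assay.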